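A few compounds are considered here, and "the series" means these few. Any claim that something is new, unique, unknown or untested is made for them only; others in the source may bear on it.

Compounds measured so far in a functional assay on LOX IMVI cells (Homo sapiens) for inhibition, read by sulforhodamine B assay, with a stated time of 48 h, tested at 10 uM; on this read-out higher numbers stand for more inhibition at the one concentration tested (going by the name of the read-out) and lower numbers for less inhibition:

- compound 1, `c1cn2cc(-c3ccsc3)nc(-c3ccc4ncn(C5CCCCC5)c4c3)c2n1`: 4.9%
- compound 2, `CC(=O)c1ccc(-c2cn3ccnc3c(-c3ccc4ncn(C5CCCCC5)c4c3)n2)cc1`: 14.5%
- compound 3, `Clc1ccc(-c2cn3ccnc3c(-c3ccc4ncn(C5CCCCC5)c4c3)n2)cc1`: 14.8%

All three share one core and differ only in the aromatic group attached to it. On the bare numbers compound 3 stands at the top of the set, but the gap a number 0.3 percentage points higher from compound 2 to compound 3 (within the scatter) and the gap a number 9.9 percentage points higher from compound 1 to compound 3 (within the scatter) are both within the scatter, so the three compounds are not separated by this assay; each gives little inhibition at the single concentration tested.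

Compound 4, `Fc1ccccc1-c1cn2ccnc2c(-c2ccc3ncn(C4CCCCC4)c3c2)n1`, has not yet been measured. It differs from compound 3 in one place: 2-fluorophenyl in place of 4-chlorophenyl on an aromatic carbon. For the measured compounds named here, no measured step swaps the position of a substituent on the phenyl ring in this way. The closest guide is the step of a number 0.3 percentage points higher from compound 2 to compound 3 (within the scatter), which shows that exchanging one substituent on the phenyl ring for another left the number essentially unchanged, and the steps of a number 9.6 percentage points higher from compound 1 to compound 2 (within the scatter) and a number 9.9 percentage points higher from compound 1 to compound 3 (within the scatter), which show that even replacing the whole thiophen-3-yl group by a substituted phenyl moved the number only within the scatter.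

Compound 4 is therefore expected to give about 12% in this assay, within 2% to 28%. The expected step of a number 2.8 percentage points lower from compound 3 to compound 4 (within the scatter) is not anticipated to exceed the scatter.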

Compound 4, a percentage reported as inhibition, at one concentration (the size of the read-out at that concentration, not a potency): 5.77%
Compound 4: middle estimate off by 6.2 percentage points, on the high side; the measured number falls inside the stated range.
By their numbers in this assay, from the lowest: compounds 1, 4, 2 and 3 (each within the scatter of the next).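

In this assay the exchange of 4-chlorophenyl for 2-fluorophenyl gives a number 9 percentage points lower from compound 3 to compound 4 (within the scatter) and is the first change shown that alters both the halogen and where it sits on the phenyl ring, yet the assay does not separate these two compounds. The other new comparisons read the same way, with a number 8.7 percentage points lower from compound 2 to compound 4 (within the scatter) for the exchange of 4-acetylphenyl and a number 0.9 percentage points higher from compound 1 to compound 4 (within the scatter) for the exchange of thiophen-3-yl, so none of the four groups placed on this aromatic carbon stands apart from the others. The result can be read only as these percentages, and nothing else shown bears on it.

Still open, on these data alone, is whether a different kind of group on this carbon, such as an amine or a carboxylic acid carried on the phenyl ring, would give a number clearly apart from these four. As far as these compounds go, the rest of the molecule is the same in all four compounds, so it also remains open how a change elsewhere on the shared core, such as a longer chain in place of the ring on its nitrogen, would read in this assay at this single concentration.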